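Extending the chain in a sigma receptor ligand series

A few compounds are considered here, and "the series" means these few. Any claim that something is new, unique, unknown or untested is made for them only; others in the source may bear on it.

Measured compounds and values:
compound 1, `CN(CCCCc1ccccc1)C1CCc2ccccc2C(O)C1`: 33 nM
compound 2, `OC1Cc2ccccc2CCC1NCCCc1ccccc1`: 1300 nM
compound 3, `OC1CC(NCCCc2ccccc2)CCc2ccccc21`: 160 nM

The three compounds were tested in an assay on cell membranes for displacement of a labelled ligand from Sigma non-opioid intracellular receptor 1 (Cavia porcellus), read by scintillation counting, with a stated time of 120 min; on this read-out higher numbers stand for weaker inhibition and lower numbers for stronger inhibition. Compound 2 gives 1300 nM, the highest number of the three. Compound 3, a positional isomer of the same chain and amine, gives 160 nM, a lower number that lies beyond the scatter, and compound 1 gives 33 nM, the lowest number of the set. Nothing but the values themselves connects these pairs.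

Compound 4, `OC1Cc2ccccc2CCC1NCCCCc1ccccc1`, has not yet been measured. It differs from compound 2 by one change: benzyl in place of phenyl on a saturated chain carbon, three bonds along the chain from an amine nitrogen. Among the compounds with values here, no measured pair isolates this chain extension, and compound 1 carries a longer chain together with other differences, so its lower number cannot be charged to the chain alone. A modest lowering is expected in this assay, not a large one. The expected step of a 2.9-fold lower number from compound 2 to compound 4 (0.46 log units; beyond the scatter) is an estimate, not a measured result. Compound 4 is estimated to give 450 nM in this assay, with a range from 150 nM to 1500 nM.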

Compound 4, inhibition constant: 430 nM
Estimate against measurement, compound 4: 1.0-fold (0.02 log units) above; measured number inside the range.
By their numbers in this assay, from the lowest: compound 1; then compound 3; then compound 4; then compound 2.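

In this assay benzyl in place of phenyl on a saturated chain carbon, three bonds along the chain from an amine nitrogen, gives a 3.0-fold lower number from compound 2 to compound 4 (0.48 log units; beyond the scatter) and so shows that this place responds to the change on its own. Within the data shown here, this is the first difference in the set that can be read in one place, with the core and the amine held the same, and the step is modest. The data offered here hold nothing that explains this step.

Still open, from the compounds shown here alone, is whether a longer chain at this place, such as phenylpentyl, would carry the step further or turn it back, and whether the same change would hold on compound 3. Also open, going by these compounds, is what a methyl on the amine nitrogen of compound 4 would do, and compound 1 differs from compound 4 in more than one place and cannot settle this.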